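A few compounds are considered here, and "the series" means these few. Any claim that something is new, unique, unknown or untested is made for them only; others in the source may bear on it.

Measured so far in an ADME assay on HepG2 2.2.15 cells (Homo sapiens) for cytotoxicity (a higher number here means that more compound is tolerated, a lower number that less compound is tolerated), as follows:
compound 1 `Cn1c(=O)c(CCO)c(-c2ccccc2Cl)c2cc(Cl)ccc21` gives 34000 nM
compound 2 `CCCC(=O)OCCc1c(-c2ccccc2Cl)c2cc(Cl)ccc2[nH]c1=O` gives 52000 nM

Only these two numbers are available in this assay for this series. Compound 2 at 52000 nM lies within the scatter of compound 1 at 34000 nM and the pair therefore sets no order. For the measured compounds named here, the two compounds also differ in more than one place, and no measured pair isolates a single change.

Compound 3 `CCOCC(=O)OCCc1c(-c2ccccc2Cl)c2cc(Cl)ccc2[nH]c1=O` is the next entry. Going by the values given here, it keeps the rest of compound 2 and carries ethoxy in place of ethyl on a saturated chain carbon bound to a carbonyl carbon as its only change. Among the compounds with values here, no measured step speaks to this replacement, so the expectation takes compound 2 at 52000 nM as its sole starting point. No shift beyond the scatter is expected in this assay and the estimated size of a 1.1-fold lower number from compound 2 to compound 3 (0.03 log units; within the scatter) reflects that. Compound 3 is estimated at 48000 nM with 20000 nM to 110000 nM as the expected range.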

Compound 3, half-maximal cytotoxic concentration: 130000 nM
The estimate for compound 3 lay 2.7-fold (0.43 log units) below the measured number, and the stated range ends below it.
By their numbers in this assay, from the lowest: compounds 1 and 2 (each within the scatter of the next); then compound 3.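

In this assay the series now has its first step at a single place: ethoxy in place of ethyl on a saturated chain carbon bound to a carbonyl carbon gives a 2.5-fold higher number from compound 2 to compound 3 (0.40 log units; beyond the scatter). This shows that the number responds to a change at this chain position, whereas the earlier pair of compounds differed in more than one place and set no order; here more compound is tolerated with ethoxy than with ethyl, although the step is a single one and rests on one pair. Nothing available bears on what lies behind this step.

As far as these compounds go, it remains open whether the oxygen of ethoxy accounts for the step or whether a plain carbon chain of the same length, such as butyl, would give a similar number. Also open, from the compounds shown here alone, is how an amine, a carboxylic acid or a longer ether chain at this place would read in this assay, and whether the same replacement would give a step of similar size on another core.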